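A few compounds are considered here, and "the series" means these few. Any claim that something is new, unique, unknown or untested is made for them only; others in the source may bear on it.

Compounds measured in a functional assay on MDA-MB-231 cells (Homo sapiens) for inhibition, read by WST assay, with a stated time of 48 h; a higher number here means a weaker inhibitor, a lower number a stronger inhibitor:

Compound 1 `O=[N+]([O-])c1cccc(/C=N\NC(=S)NC2CCCCC2)c1` gives 84800 nM in this assay.
Compound 2 `Oc1cccc(/C=N\NC(=S)NC2CCCCC2)c1` gives 24500 nM in this assay.
Compound 3 `Oc1ccc(/C=N\NC(=S)NC2CCCCC2)cc1` gives 115000 nM in this assay.

Compound 2 has the lowest number of the three; compound 1 stands nearest to it and compound 3 furthest, and both of those gaps lie beyond the scatter. Among the compounds with values here, the only single-point step among the measured compounds is a 3.5-fold lower number from compound 1 to compound 2 (0.54 log units; beyond the scatter), a hydroxy in place of a nitro on an aromatic carbon, which is a modest step. Compound 2 and compound 3 share the same groups and differ only in where the hydroxy sits, and their numbers lie apart by more than the scatter.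

Compound 4 `COc1cccc(/C=N\NC(=S)NC2CCCCC2)c1` is not yet measured. It differs from compound 2 by methyl in place of hydrogen on an oxygen on an aromatic ring. No measured step bears on this change: nothing shown here replaces a hydrogen on an oxygen by a methyl, so the one step that is known, the nitro-to-hydroxy exchange, gives no direct guide. The expectation is therefore for a step no larger than the scatter, or a small one, with the direction uncertain. For compound 4 the expected value in this assay is 35000 nM, within a range from 12000 nM to 100000 nM, which means an expected step of a 1.4-fold higher number from compound 2 to compound 4 (0.15 log units; within the scatter).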

Compound 4, half-maximal inhibitory concentration: 88900 nM
The estimate for compound 4 lay 2.5-fold (0.40 log units) below the measured number; the measured number falls inside the stated range.
By their numbers in this assay, from the lowest: compound 2; then compounds 1, 4 and 3 (each within the scatter of the next).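

In this assay, methyl in place of hydrogen on the oxygen gives a 3.6-fold higher number from compound 2 to compound 4 (0.56 log units; beyond the scatter) and so shows what the nitro-to-hydroxy step could not: at this place, the hydroxy of compound 2 cannot be capped with a methyl without the number rising beyond the scatter. The second new comparison, a 1.0-fold higher number from compound 1 to compound 4 (0.02 log units; within the scatter) in the same assay, puts methoxy and nitro level, so among the three groups seen at this place only hydroxy stands apart, with the lower number on both of its steps. The data shown offer no explanation for this difference between hydroxy and methoxy.

What the compounds leave open is whether only the free hydroxy holds the number of compound 2 at this place, or whether an amine or a carboxylic acid there would do the same. Also open, from the compounds shown here alone, is whether a longer chain on the oxygen, such as ethoxy, would go further than methoxy, and whether a methyl on the oxygen of compound 3 would produce a step of the same direction and size.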